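Replacing the oxadiazole of compound 2 with a hydantoin

A few compounds are considered here, and "the series" means these few. Any claim that something is new, unique, unknown or untested is made for them only; others in the source may bear on it.

Going by the values given here, compound 2 `CCCCOC(=O)NS(=O)(=O)c1sc(CC(C)C)cc1-c1ccc(Cc2nnc(C(F)(F)F)o2)cc1` gives 328 nM in an assay on membranes from uterus for displacement of a labelled ligand from Angiotensin type II receptor (Sus scrofa), with a stated time of 1.5 h (on this read-out lower numbers stand for stronger inhibition and higher numbers for weaker inhibition), the higher of the two numbers so far; compound 1 `CCCCOC(=O)NS(=O)(=O)c1sc(CC(C)C)cc1-c1ccc(Cn2ncnn2)cc1` gives 16 nM, and the step of a 21-fold higher number from compound 1 to compound 2 (1.31 log units; beyond the scatter) shows that the ring on the saturated chain carbon bound to an aromatic carbon matters. Compound 3 `CCCCOC(=O)NS(=O)(=O)c1sc(CC(C)C)cc1-c1ccc(CN2C(=O)N(C)C(C)(C)C2=O)cc1` carries 3,4,4-trimethyl-2,5-dioxoimidazolidin-1-yl in place of 5-(trifluoromethyl)-1,3,4-oxadiazol-2-yl on a saturated chain carbon bound to an aromatic carbon. Among the compounds with values here, only that one measured step bears on this change, and it gives no direction for a non-aromatic ring, so a step of a 1.3-fold lower number from compound 2 to compound 3 (0.12 log units; within the scatter) is expected, with wide uncertainty either way. Compound 3 is therefore estimated at 250 nM, between 50 nM and 1200 nM.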

Compound 3, inhibition constant: 3.6 nM
Compound 3: middle estimate off by 69-fold (1.84 log units), on the high side; measured number outside the range, below it.
By their numbers in this assay, from the lowest: compound 3; then compound 1; then compound 2.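

At this position, on a saturated chain carbon bound to an aromatic carbon, the ring need not be aromatic: 3,4,4-trimethyl-2,5-dioxoimidazolidin-1-yl gives a 91-fold lower number from compound 2 to compound 3 (1.96 log units; beyond the scatter) and a 4.4-fold lower number from compound 1 to compound 3 (0.65 log units; beyond the scatter). Compound 3 therefore has the lowest number of the three, and both steps lie beyond the scatter. Nothing shown accounts for this difference.

From the compounds shown here alone, whether the methyl groups or the carbonyls of the new ring drive the change remains open. Also open, going by these compounds, is how an open-chain urea or a carboxylic acid on the same carbon would compare.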